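This account rests on a few compounds, and the source may have more. Where it says the series, first, only, none or still open, it means among the compounds named here.

In a functional assay on A549 cells (Homo sapiens) for cytotoxicity, read by MTT assay, with a stated time of 72 h (on this read-out lower numbers stand for stronger inhibition and higher numbers for weaker inhibition), compound 3 `O=C1c2c[n+]([O-])c3ccccc3c2C(=O)c2c1c1ccccc1n2Cc1cn(CC(O)CO)nn1` gives 880 nM, the highest number among the three measured compounds. Compound 1 `CN(C)CCCCCn1c2c(c3ccccc31)C(=O)c1c[n+]([O-])c3ccccc3c1C2=O` gives 210 nM and compound 2 `O=C1c2c[n+]([O-])c3ccccc3c2C(=O)c2c1c1ccccc1n2Cc1cn([C@@H]2C[C@H](O)[C@@H](CO)O2)nn1` gives 120 nM. The unmeasured compound 4 `O=C1c2c[n+]([O-])c3ccccc3c2C(=O)c2c1c1ccccc1n2CCN1CCCC1` differs from compound 3 on a saturated chain carbon bound to an aromatic nitrogen: (pyrrolidin-1-yl)methyl in place of 1-(2,3-dihydroxypropyl)-1H-1,2,3-triazol-4-yl on a saturated chain carbon bound to an aromatic nitrogen.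

The closest measured precedent is a 4.2-fold higher number from compound 1 to compound 3 (0.62 log units; beyond the scatter), which removes 4-(dimethylamino)butyl and brings in the same 1-(2,3-dihydroxypropyl)-1H-1,2,3-triazol-4-yl that compound 4 gives up. Read in reverse, it points to a lower number for compound 4. The second step, a 7.3-fold higher number from compound 2 to compound 3 (0.87 log units; beyond the scatter), is a caution: compound 2 keeps a triazole and still has the lowest number, so the triazole alone does not go with weak inhibition. Among the measured compounds shown here, the data also hold no measured compound with (pyrrolidin-1-yl)methyl.

A modest step towards a lower number, beyond the scatter, is therefore expected in this assay: a 2.9-fold lower number from compound 3 to compound 4 (0.47 log units; beyond the scatter). For compound 4 the estimated value is 300 nM, with an expected range of 110 nM to 800 nM.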

Compound 4, half-maximal inhibitory concentration: 410 nM
Beside the measured number, compound 4's estimate is 1.4-fold (0.14 log units) below it; the measured number falls inside the stated range.
By their numbers in this assay, from the lowest: compounds 2, 1 and 4 (each within the scatter of the next, the first and the last beyond it); then compound 3.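

In this assay, exchanging (1-(2,3-dihydroxypropyl)-1H-1,2,3-triazol-4-yl)methyl for 2-(pyrrolidin-1-yl)ethyl gives a 2.1-fold lower number from compound 3 to compound 4 (0.33 log units; beyond the scatter), so this position accepts a side chain with neither triazole nor hydroxyl groups without a rise in the number. Against the open-chain amine, the result is a 2.0-fold higher number from compound 1 to compound 4 (0.29 log units; within the scatter), so the data do not separate the pyrrolidine ring from the 4-(dimethylamino)butyl end, and compound 2, with its triazole, goes against any link between triazole and a higher number. Nothing in the data gives a reason for these differences.

Still open, going by these compounds, is whether a piperidine or morpholine on the same ethyl chain would track with compound 4. Also open, on these data alone, is whether a carboxylic acid at the chain end would keep the number in this range.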